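The source may hold more compounds than are shown below. What is called first, only, known or untested is meant among the compounds shown, and "the series" means these compounds.

Working notes on the cytotoxicity series

The series is assessed in an ADME assay on L02 cells (Homo sapiens) for cytotoxicity, read by MTT assay, with a stated time of 72 h; on this read-out lower numbers stand for stronger inhibition and higher numbers for weaker inhibition. Compound 1 `COc1cccc(Nc2nc3c(c(Oc4cccc(NC(=O)C=C(C)C)c4)n2)CSCC3)c1` carries a 2-methylprop-1-en-1-yl group on a carbonyl carbon and a 3-methoxyphenyl group on a nitrogen on an aromatic ring. In this assay compound 1 returns only a limit, > 50000 nM. Compound 2 `COc1cccc(Nc2nc3c(c(Oc4cccc(NC(=O)/C=C/C(C)C)c4)n2)CSCC3)c1` differs from compound 1 by 3-methylbut-1-en-1-yl in place of 2-methylprop-1-en-1-yl on a carbonyl carbon. In this assay compound 2 likewise returns only a limit, > 50000 nM. The step that the two limits leave unreadable from compound 1 to compound 2 therefore cannot be read; both ends sit at the limit (the limit of > 50000 nM in this assay, at which 3 of the 3 values shown sit).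

Compound 3 `COc1ccc(Nc2nc3c(c(Oc4cccc(NC(=O)C=C(C)C)c4)n2)CSCC3)cc1` differs from compound 1 by 4-methoxyphenyl in place of 3-methoxyphenyl on a nitrogen on an aromatic ring. In this assay compound 3 again returns only a limit, > 50000 nM. The step that the two limits leave unreadable from compound 1 to compound 3 is unreadable for the same reason, as all three values sit at the limit of > 50000 nM in this assay, at which 3 of the 3 values shown sit.

Compound 4 `COc1ccc(Nc2nc3c(c(Oc4cccc(NC(=O)/C=C/C(C)C)c4)n2)CSCC3)cc1` is not yet measured. It differs from compound 3 by 3-methylbut-1-en-1-yl in place of 2-methylprop-1-en-1-yl on a carbonyl carbon. The place of this change, a carbonyl carbon whose other neighbours are an amide-type nitrogen, is identical to the place of the change from compound 1 to compound 2, so the change is the same one, made on the core of compound 3 rather than on the core of compound 1. Since the earlier pass of this change left both ends at the limit of > 50000 nM in this assay, at which 3 of the 3 values shown sit, compound 4 is expected to give a step of a number no higher from compound 3 to compound 4 (the limit leaves the size open) in this assay, that is, no measurable shift. Compound 4 is estimated at 50000 nM in this assay, most probably reported as a limit again, with a range of 25000 nM to 100000 nM.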

Compound 4, half-maximal inhibitory concentration: > 50000 nM
Compound 4: a limit, no number; the forecaster's own chance of this, stated with the estimate: 85%; the middle value lies on the limit itself.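

Compound 4 also returns only a limit, so neither the step from compound 3 to compound 4 nor the step from compound 2 to compound 4 can be read, and no new step emerges: the limit of > 50000 nM in this assay, at which 4 of the 4 values shown sit.

The compounds shown leave open whether 3-methylbut-1-en-1-yl in place of 2-methylprop-1-en-1-yl, or 4-methoxyphenyl in place of 3-methoxyphenyl, changes the result in this assay at all.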